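The source may report more compounds than this note shows. Statements on the series, on what has been measured and on what is new or still open speak of the compounds shown alone.

Measured in a functional assay on SNB-19 cells (Homo sapiens) for inhibition, read by MTT assay, with a stated time of 7 days; on this read-out higher numbers stand for weaker inhibition of growth and lower numbers for stronger inhibition of growth:
Compound 1 `NC(=O)c1ncn2c(=O)n(Cc3ccco3)nnc12`: > 50000 nM
Compound 2 `CC[C@@H](c1ccccc1)n1nnc2c(C(N)=O)ncn2c1=O`: > 50000 nM
Compound 3 `NC(=O)c1nc[nH]c1N/N=N/Cc1ccccc1`: > 50000 nM

All three entries are limits and not numbers, so the series stands at the limit of > 50000 nM in this assay, at which 3 of the 3 values shown sit. Compound 3 therefore has only the limit > 50000 nM as its position. Compound 4 `NC(=O)c1nc[nH]c1N/N=N/Cc1ccoc1` carries furan-3-yl in place of phenyl on a saturated chain carbon bound to a double-bonded nitrogen. For the measured compounds named here, no measured pair gives the size of such a change, so no step beyond the scatter is expected in either direction in this assay. The expected step is a number no higher from compound 3 to compound 4 (the limit leaves the size open). For compound 4 the estimate is 50000 nM, with an expected range of 25000 nM to 100000 nM.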

Compound 4, concentration for 50% growth inhibition: > 50000 nM
Compound 4: no number, only a limit; the forecaster's own chance of this, stated with the estimate: 85%; the middle value lies on the limit itself.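

For compound 3 and compound 4 no step can be read in this assay since both entries are limits and not numbers: the limit of > 50000 nM in this assay, at which 4 of the 4 values shown sit.

The compounds shown leave open whether furan-3-yl in place of phenyl changes the result in this assay at all.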